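Sulfonamide series: pyridin-4-yl in place of 3-methylphenyl

The source may hold more compounds than are shown below. What is called first, only, known or untested is meant among the compounds shown, and "the series" means these compounds.

Measured compounds, all in an assay on isolated protein for inhibition of alkaline phosphatase, tissue-nonspecific isozyme (Homo sapiens); on this read-out lower numbers stand for stronger inhibition and higher numbers for weaker inhibition:
compound 1, `COc1ccc(Cl)cc1S(=O)(=O)Nc1cncc(C(=O)Nc2ccccc2)c1`: "not determined" (no result reported)
compound 2, `COc1ccc(Cl)cc1S(=O)(=O)Nc1cncc(C(=O)O)c1`: > 20000 nM, a limit of the assay and not a number
compound 3, `COc1ccc(Cl)cc1S(=O)(=O)Nc1cncc(-c2cccc(C)c2)c1`: "not determined" (no result reported)

Compound 3 stands without a number of its own in this assay. Going by the values given here, of the two other entries, the one for compound 2 is a limit and the one for compound 1 is also without a number. Among the compounds with values here, the only evidence across the set is therefore (the limit of > 20000 nM in this assay, at which 1 of the 3 values shown sits). Within the data shown here, no step between measured compounds can be drawn, so the series offers no measured size of change to lean on.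

Compound 4, `COc1ccc(Cl)cc1S(=O)(=O)Nc1cncc(-c2ccncc2)c1`, is compound 3 with a single change: pyridin-4-yl in place of 3-methylphenyl on an aromatic carbon. The shared core is kept; only the group on the aromatic carbon two atoms from the ring nitrogen differs, a six-membered aromatic ring with one hetero atom taking the place of a six-membered aromatic ring of carbon only.

Among the measured compounds shown here, with no measured step in this assay, the size of the step from compound 3 to compound 4 cannot be read from the series; a change within the scatter is as plausible as one beyond it, in either direction. For the measured compounds named here, the one value that exists sits at the limit, so the only anchor is weak inhibition. Compound 4 is therefore expected to give about 15000 nM, with a range from 3000 nM to 30000 nM, and a fair chance that only a limit is reported.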

Compound 4, half-maximal inhibitory concentration: > 20000 nM
Compound 4: only a limit was reported; the forecaster's own chance of this, stated with the estimate: 50%; middle value at least 1.3-fold (0.12 log units) away from the limit.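

Compound 2 and compound 4 each carry only a limit, not a number, in this assay, so no step between them can be read: the limit of > 20000 nM in this assay, at which 2 of the 4 values shown sit.

The compounds shown leave open whether pyridin-4-yl in place of 3-methylphenyl changes inhibition in this assay, and how strongly any of these compounds inhibits.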